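The compounds below may be only part of what the source reports. "The series", "measured", "known", "first", "only" and "open" are said of these compounds alone.

Measured in a functional assay on LNCaP cells (Homo sapiens) for cytotoxicity, read by sulforhodamine B assay, with a stated time of 48 h; a higher number here means a weaker inhibitor, a lower number a stronger inhibitor:
- compound 1 `COc1cc(NC(=O)[C@H]2CSC(c3ccccc3)=N2)cc(OC)c1OC`: 16800 nM
- compound 2 `CCCCCCCCCCCCCCCCC(=O)c1csc(-c2ccccc2)n1`: > 20000 nM
- compound 3 `CCc1ccc(-c2nc(C(=O)c3cc(OC)c(OC)c(OC)c3)cs2)cc1`: 60 nM

Only two of these results are actual numbers, and compound 1 has the higher one at 16800 nM. Compound 3 gives 60 nM, a lower number by a gap well beyond the scatter. Compound 2 gives only a limit, > 20000 nM.

The next compound to be tested is compound 4 `COc1cc(NC(=O)[C@@H]2CSC(c3ccccc3)=N2)cc(OC)c1OC`. Its difference from compound 1 is the two compounds have the same atoms and bonds and differ only in configuration as drawn: 1 of 1 stereo elements differ; a stereocentre at a saturated ring carbon is drawn S in compound 1 and R in compound 4. The two compounds have the same atoms and bonds, and a stereocentre at a saturated ring carbon is drawn S in compound 1 and R in compound 4.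

Going by the values given here, no measured pair in this set shows what such a change of configuration does in this assay. The expectation therefore starts from compound 1 at 16800 nM and foresees no step beyond the scatter, in either direction. The estimated step is a 1.2-fold lower number from compound 1 to compound 4 (0.08 log units; within the scatter). For compound 4 the expected value is 14000 nM, with an estimated range of 6000 nM to 20000 nM.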

Compound 4, half-maximal inhibitory concentration: > 20000 nM
Compound 4: no number, only a limit; the forecaster's own chance of this, stated with the estimate: 20%; middle value at least 1.4-fold (0.15 log units) from the limit.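

Going by these compounds alone, changing the drawn configuration at the saturated ring carbon is the first change in this set that can be read as a step, and in this assay it gives an at least 1.1-fold higher number from compound 1 to compound 4 (0.07 log units; that floor lies within the scatter). For compound 4 the result is a limit, > 20000 nM, and not a number. Any difference between this pair could come only from the stereocentre, because nothing else separates them: the fact that compounds 1 and 4 differ only in the configuration as drawn.

On these data alone, how far apart the two mirror-drawn forms really lie stays open, because the reading for compound 4 ends at a limit shared with another compound: the limit of > 20000 nM in this assay, at which 2 of the 4 values shown sit. Also open, as far as these compounds go, is whether adding a carboxylic acid or an amine to the core of compound 1 would make the drawn configuration matter in this assay.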